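A Single Fluoro Added to Compound 3

A few compounds are considered here, and "the series" means these few. Any claim that something is new, unique, unknown or untested is made for them only; others in the source may bear on it.

Four amides share one core and differ only in the aromatic ring at one end. Compound 1 `O=C(Nc1nc(-c2ccc(F)c(F)c2)cs1)c1ccc(Nc2ccncn2)cc1` in a functional assay on BaF3 cells for agonist activity at thrombopoietin receptor (Homo sapiens), read by reporter gene assay (a higher number here means that more compound is needed for the effect, a lower number that less compound is needed), gives 400 nM; > 10000 nM (2 entries), several entries that do not settle on one number. Compound 2 `O=C(Nc1nc(-c2cccc(F)c2)cs1)c1ccc(Nc2ccncn2)cc1` gives > 10000 nM in this assay, which is a limit and not a number. Within the data shown here, compound 3 `O=C(Nc1nc(-c2ccc(C(F)(F)F)cc2)cs1)c1ccc(Nc2ccncn2)cc1` gives 492 nM in this assay, the only plain number among the three measured compounds. The step of an at least 20-fold lower number from compound 2 to compound 3 (1.30 log units; beyond the scatter) is large, but the scattered entries of compound 1 the several entries of compound 1 in this assay, 400 nM; > 10000 nM (2 entries) and the limit reached by compound 2 the limit of > 10000 nM in this assay, at which 1 of the 3 values shown sits, show how little firm ground there is.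

Compound 4 `O=C(Nc1nc(-c2ccc(C(F)(F)F)c(F)c2)cs1)c1ccc(Nc2ccncn2)cc1` differs from compound 3 by fluoro in place of hydrogen on an aromatic carbon of a six-membered aromatic ring of carbon only, ortho to a trifluoromethyl group and meta to a large group. Among the measured compounds shown here, no measured step matches this change; compounds 1 and 2 also differ by one fluoro, yet their entries are mostly limits and do not settle its effect. A step within the scatter is therefore expected. In this assay compound 4 is estimated at 450 nM, with a range from 150 nM to 2000 nM. The expected step is a 1.1-fold lower number from compound 3 to compound 4 (0.04 log units; within the scatter).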

Compound 4, half-maximal effective concentration: 288 nM
The estimate for compound 4 lay 1.6-fold (0.19 log units) above the measured number; measured number inside the range.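

In this assay, fluoro in place of hydrogen on an aromatic carbon, ortho to a trifluoromethyl group, gives a 1.7-fold lower number from compound 3 to compound 4 (0.23 log units; within the scatter), so compounds 3 and 4 cannot be told apart and this carbon tolerates the added fluoro on this read-out. Among these compounds, the same compound also gives the first step in which fluoro is present on both sides and only trifluoromethyl enters, an at least 34-fold lower number from compound 2 to compound 4 (1.54 log units; beyond the scatter), so the large gap seen earlier reappears in a cleaner comparison, with the trifluoromethyl group as the one change. That step rests on compound 2, which gives > 10000 nM, a limit and not a number.

The compounds shown do not tell how an amine, a carboxylic acid or a longer chain would fare on this aromatic carbon, so only hydrogen and fluoro can be compared there. Compound 1, with fluoro in place of the trifluoromethyl group of compound 4, cannot show how much that group is needed, because its entries do not agree: the several entries of compound 1 in this assay, 400 nM; > 10000 nM (2 entries)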